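Solubility notes: trimming the difluoroalkyl chain in compound 3

A few compounds are considered here, and "the series" means these few. Any claim that something is new, unique, unknown or untested is made for them only; others in the source may bear on it.

Three compounds of the series have numbers in a physicochemical assay for solubility, at pH 6.5; on this read-out lower numbers stand for lower solubility and higher numbers for higher solubility. Compound 1 `COCc1nc2nc(C)cc(Nc3ccc(C(F)(F)F)cc3)n2n1` gives 150000 nM, compound 2 `Cc1cc(Nc2ccc(C(F)(F)F)cc2)n2nc(C3CC3)nc2n1` gives 38000 nM, and compound 3 `CCC(F)(F)c1nc2nc(C)cc(Nc3ccc(S(F)(F)(F)(F)F)cc3)n2n1` gives 15000 nM, the lowest of the three. Within the data shown here, the one single-point step so far, a 3.9-fold lower number from compound 1 to compound 2 (0.60 log units; beyond the scatter), concerns a different position on the core and does not reach the change now considered.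

Compound 4 `Cc1cc(Nc2ccc(S(F)(F)(F)(F)F)cc2)n2nc(C(C)(F)F)nc2n1` differs from compound 3 by hydrogen in place of methyl on a saturated chain carbon, two bonds along the chain from an aromatic carbon and two fluorine atoms, so 1,1-difluoropropyl becomes 1,1-difluoroethyl. Among the measured compounds shown here, no measured step mirrors this loss of one chain carbon; a small move toward higher solubility is the plain expectation, barely beyond the scatter if at all. For compound 4 the estimate is 25000 nM, range 12000 nM to 55000 nM, meaning an expected step of a 1.7-fold higher number from compound 3 to compound 4 (0.22 log units; within the scatter).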

Compound 4, solubility: 30000 nM
Beside the measured number, compound 4's estimate is 1.2-fold (0.08 log units) below it; measured number inside the range.
By their numbers in this assay, from the lowest: compounds 3, 4 and 2 (each within the scatter of the next, the first and the last beyond it); then compound 1.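

In this assay, among these compounds, the first reading at this chain position is a 2.0-fold higher number from compound 3 to compound 4 (0.30 log units; within the scatter), so 1,1-difluoropropyl and 1,1-difluoroethyl cannot be told apart on this read-out. Loss of the methyl therefore leaves no separable effect in this single pair. Nothing at hand bears on the reason for this step.

Open, going by these compounds, is whether a longer chain, an amine or a carboxylic acid on this saturated chain carbon would give a step beyond the scatter. Also open, on these data alone, is whether 1,1-difluoroethyl and hydrogen-bearing chains without the two fluorine atoms would read alike.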